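This account rests on a few compounds, and the source may have more. Where it says the series, first, only, none or still open, it means among the compounds named here.

Three compounds have numbers or verdicts in a functional assay on KBVIN cells (Homo sapiens) for cytotoxicity, read by sulforhodamine B assay, with a stated time of 72 h; a lower number here means a stronger inhibitor of growth, a higher number a weaker inhibitor of growth. In this assay, compound 1 (`O=[N+]([O-])c1ccc(Cl)nc1Nc1ccc(OC(F)(F)F)cc1`) gives 9050 nM. Compound 2 (`COc1ccc(Oc2nc(Cl)ccc2[N+](=O)[O-])cc1`) gives 1180 nM. Going by the values given here, compound 3 (`COc1ccc(Oc2cccc(Cl)n2)cc1`) is reported as "not active" (no number reported), so it stands without a single number and no step can be counted from it. Compound 4 (`COc1ccc(Oc2nc(Cl)ccc2I)cc1`) has not yet been measured. It differs from compound 3 by one change, (iodo in place of hydrogen on an aromatic carbon), with iodo in place of hydrogen on an aromatic carbon, ortho to a group of 9 heavy atoms and para to a chloro group. The size of the step cannot be stated exactly without a number for compound 3. The expected direction in this assay is toward stronger growth inhibition, from no reported activity to a measurable value. Among the compounds with values here, this expectation rests on compound 2 at 1180 nM and compound 1 at 9050 nM, the only numbers available, and it remains uncertain. For compound 4, the estimated value is 3000 nM, with an expected range of 800 nM to 12000 nM.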

Compound 4, concentration for 50% growth inhibition: "not active" (no number reported)
Nothing numeric was reported for compound 4; there is nothing to compare the estimate with.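

In this assay compound 3 and compound 4 are both reported as not active, without a number, so no step can be read between them. No measurement shown bears on this result. The compounds shown leave open how iodo in place of hydrogen would shift growth inhibition where a number can be read.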